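The source may hold more compounds than are shown below. What is called first, only, known or untested is meant among the compounds shown, and "the series" means these compounds.

- Compound 1 `O=C(CC(c1ccc(Cl)cc1)C(C(=O)Nc1ccccn1)C(=O)Nc1ccccn1)c1ccccc1`: 19100 nM
- Compound 2 `O=C(CC(c1ccc(Cl)cc1)C(C(=O)Nc1ccccn1)C(=O)Nc1ccccn1)c1ccc(F)cc1`: 21200 nM
- Compound 3 `COc1ccc(C(CC(=O)c2ccccc2)C(C(=O)Nc2ccccn2)C(=O)Nc2ccccn2)cc1`: not yet measured

In a functional assay on MCF7 cells (Homo sapiens) for inhibition, read by MTT assay, with a stated time of 48 h (a lower number here means a stronger inhibitor, a higher number a weaker inhibitor), compound 1 at 19100 nM and compound 2 at 21200 nM stand within the scatter of each other. Compound 3 carries methoxy in place of chloro on an aromatic carbon, para to a large group: methoxy in place of chloro on an aromatic carbon. Going by the values given here, the only measured step, a 1.1-fold higher number from compound 1 to compound 2 (0.05 log units; within the scatter), is a different change, fluoro in place of hydrogen, and no measured step touches the chloro. Among the compounds with values here, with only that small step as a guide, no shift beyond the scatter is expected, and the direction stays open. The expected step is a 1.2-fold higher number from compound 1 to compound 3 (0.06 log units; within the scatter). Compound 3 is estimated at 22000 nM, with an expected range of 11000 nM to 45000 nM.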

Compound 3, half-maximal inhibitory concentration: 48300 nM
Compound 3: the middle estimate sits 2.2-fold (0.34 log units) below what was measured, outside the stated range (above it).
By their numbers in this assay, from the lowest: compounds 1 and 2 (each within the scatter of the next); then compound 3.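

In this assay, replacing chloro with methoxy at this position gives a 2.5-fold higher number from compound 1 to compound 3 (0.40 log units; beyond the scatter) and so moves the number beyond the scatter, which the earlier fluoro change elsewhere on the shared core did not do. This position is therefore not indifferent to substitution, and 4-chlorophenyl is favoured over 4-methoxyphenyl here. No evidence bears on why the number rises. The compounds shown leave open how hydrogen, an amine or a hydroxyl on the same carbon would compare with chloro, and whether any replacement gives a lower number than compound 1 does.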